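Trading chloro for fluoro on an aromatic carbon

A few compounds are considered here, and "the series" means these few. Any claim that something is new, unique, unknown or untested is made for them only; others in the source may bear on it.

Compound 1 `COc1cccc(NC(=S)N/N=C/c2ccc3ccccc3n2)c1`: 74500 nM
Compound 2 `S=C(N/N=C/c1ccc2ccccc2n1)Nc1cccc(Cl)c1`: 52500 nM

Going by the values given here, in a functional assay on HeLa cells (Homo sapiens) for antiproliferative activity, read by sulforhodamine B assay, with a stated time of 72 h (a lower number here means a stronger inhibitor, a higher number a weaker inhibitor), only these two compounds have numbers so far. Among the compounds with values here, compound 2 gives 52500 nM, and its only point of comparison is compound 1 at 74500 nM. The gap between them is a 1.4-fold lower number from compound 1 to compound 2 (0.15 log units; within the scatter), so the two cannot be ranked.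

Compound 3 `Fc1cccc(NC(=S)N/N=C/c2ccc3ccccc3n2)c1` keeps the shared core and changes one group: fluoro in place of chloro on an aromatic carbon. In words, this is fluoro in place of chloro on an aromatic carbon, or 3-chlorophenyl to 3-fluorophenyl.

Within the data shown here, one measured step bears on this, the swap of methoxy for chloro in a 1.4-fold lower number from compound 1 to compound 2 (0.15 log units; within the scatter). That single swap stayed small, so no change beyond the scatter is expected in this assay, and no direction can be called. The expected move is a 1.1-fold higher number from compound 2 to compound 3 (0.06 log units; within the scatter). Compound 3 is estimated at 60000 nM, within an expected range of 25000 nM to 120000 nM.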

Compound 3, half-maximal inhibitory concentration: 70100 nM
Compound 3: the middle estimate sits 1.2-fold (0.07 log units) below what was measured, and the stated range covers the measured number.
By their numbers in this assay, from the lowest: compounds 2, 3 and 1 (each within the scatter of the next).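

In this assay, fluoro in place of chloro on an aromatic carbon gives a small step (a 1.3-fold higher number from compound 2 to compound 3 (0.13 log units; within the scatter)), and fluoro in place of methoxy gives another (a 1.1-fold lower number from compound 1 to compound 3 (0.03 log units; within the scatter)). With the earlier step, all three groups tried at this one place, methoxy, chloro and fluoro, now lie within the scatter of each other, so none of them can be ranked above another, and this change in the 3-substituted phenyl group has not shifted the number in any readable way. No measurement here gives a reason for this sameness.

Going by these compounds, it stays open whether any group at this place can move the number beyond the scatter, for example an amine, a carboxylic acid or a longer chain such as butoxy. On these data alone, it also stays open whether the same small steps would hold for a group at another place on this ring.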